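An Acetyl in Place of the Sulfoxide

A few compounds are considered here, and "the series" means these few. Any claim that something is new, unique, unknown or untested is made for them only; others in the source may bear on it.

Three compounds of a shared core have been examined in an assay on cells (Hepatocyte) for inhibition of glucokinase regulatory protein (Mus musculus), with stated times of 20 min and 40 min; a higher number here means that more compound is needed for the effect, a lower number that less compound is needed. Compound 1 `CC#C[C@H]1CN(S(=O)(=O)c2ccc(N)nc2)CCN1c1ccc(S(=O)(=O)NC)cn1` gives 381 nM in this assay. Compound 2 `CC#C[C@H]1CN(S(=O)(=O)c2ccc(N)nc2)CCN1c1ccc([S+](C)[O-])cc1` returns only a limit of the assay, reported as > 12500 nM. Compound 3 `CC#C[C@H]1CN(S(=O)(=O)c2ccc(N)nc2)CCN1c1ncc(C(O)(C(F)(F)F)C(F)(F)F)s1` likewise returns only a limit, > 12500 nM. Compound 2 therefore stands at the limit of > 12500 nM in this assay, at which 2 of the 3 values shown sit, and no number is known for it beyond that limit. Within the data shown here, no pair of measured compounds differing in a single place is available, so no measured step can be set beside the change considered here.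

Compound 4 `CC#C[C@H]1CN(S(=O)(=O)c2ccc(N)nc2)CCN1c1ccc(C(C)=O)cc1` differs from compound 2 by a group of 3 heavy atoms (2 carbon, 1 oxygen; no ring) in place of a group of 3 heavy atoms (1 carbon, 1 oxygen, 1 sulfur; no ring), on an aromatic carbon. With compound 2 known only as a limit, the size of the step cannot be anchored to a number. The expected step of an at least 2.5-fold lower number from compound 2 to compound 4 (0.39 log units; beyond the scatter) is taken to point toward a smaller value in this assay, though with a substantial chance that compound 4 also comes back as a limit. Compound 4 is estimated to give 5000 nM in this assay, within a range from 800 nM to 12500 nM.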

Compound 4, half-maximal effective concentration: > 12500 nM
Compound 4: a limit, no number; the forecaster's own chance of this, stated with the estimate: 45%; middle value at least 2.5-fold (0.39 log units) from the limit.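

In this assay compound 4 returns only a limit, > 12500 nM. Compound 2 and compound 4 are thus both known only as limits, so no step between them can be read: the limit of > 12500 nM in this assay, at which 3 of the 4 values shown sit.

The compounds shown leave open whether the acetyl or the group it replaces gives the lower number, and how far past the limit either compound lies.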